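The source may hold more compounds than are shown below. What is called first, only, known or untested is meant among the compounds shown, and "the series" means these compounds.

The measured compounds:
Compound 1, `CC(C)/C(=C1\C(=O)NC(=O)N1C)c1ccc(-c2ccc3cccc(F)c3c2)[nH]c1=O`, gives 11100 nM in a physicochemical assay for solubility, measured as kinetic solubility, at pH 2; on this read-out higher numbers stand for higher solubility and lower numbers for lower solubility.
Compound 2, `CCC(CC)C(/C=C1\OC(=O)NC1=O)c1ccc(-c2ccc3cccc(F)c3c2)[nH]c1=O`, gives 3680 nM in this assay.
Compound 3, `CC(C)[C@@H](c1ccc(-c2ccc3cccc(F)c3c2)[nH]c1=O)[C@H]1OC(=O)NC1=O`, gives 5400 nM in this assay.

Among these three numbers, compound 3 holds the second highest. Its value and that of compound 2 lie within the usual scatter of each other, so the two cannot be told apart on this evidence. The gap from compound 3 to compound 1 is wider and lies beyond the scatter, so compound 1 does stand higher than compound 3 in this assay.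

Compound 4, `CC(C)[C@H](C[C@@H]1OC(=O)NC1=O)c1ccc(-c2ccc3cccc(F)c3c2)[nH]c1=O`, has not yet been measured. It arises from compound 3 through a single change:

(2,4-dioxo-1,3-oxazolidin-5-yl)methyl in place of 2,4-dioxo-1,3-oxazolidin-5-yl on a saturated chain carbon bound to an aromatic carbon and a saturated chain carbon

Everything else in the molecule stays the same. For the measured compounds named here, no pair of measured compounds shows this same change, so its effect cannot be read off from the numbers already in hand. The step is expected to be small, a 1.2-fold lower number from compound 3 to compound 4 (0.08 log units; within the scatter), and not beyond the scatter in either direction. Compound 4 is therefore expected to give about 4500 nM, within a range from 1500 nM to 13000 nM.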

Compound 4, solubility: 25100 nM
Beside the measured number, compound 4's estimate is 5.6-fold (0.75 log units) below it; the whole stated range lies below it.
By their numbers in this assay, from the lowest: compounds 2 and 3 (each within the scatter of the next); then compound 1; then compound 4.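

Replacing 2,4-dioxo-1,3-oxazolidin-5-yl with (2,4-dioxo-1,3-oxazolidin-5-yl)methyl on a saturated chain carbon bound to an aromatic carbon and a saturated chain carbon gives, in this assay, a 4.6-fold higher number from compound 3 to compound 4 (0.67 log units; beyond the scatter), so the read-out at this position is not indifferent to this change. Both groups hold the same five-membered ring, the same counts of hydrogen-bond donors and acceptors, and no net charge, so the step comes without any change in those counts. Nothing measured here explains the step.

As far as these compounds go, whether a longer chain in place of the methyl would carry the step further, or whether a carboxylic acid or an amine at this position would give a similar number, remains open. Compound 1 and compound 2 differ from compound 3 in more than one place, so they cannot settle either question.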